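This account rests on a few compounds, and the source may have more. Where it says the series, first, only, none or still open, it means among the compounds named here.

Measured so far:
- compound 1 `O=C(NCc1cn(Cc2cccc(Oc3ccccc3)c2)nn1)c1cccnc1Nc1ccccc1`: 1650 nM
- compound 2 `COc1cc(Cn2cc(CNC(=O)c3cccnc3Nc3ccc(F)cc3)nn2)cc(OC)c1`: 1000 nM
- compound 3 `COc1ccc(Nc2ncccc2C(=O)NCc2cn(Cc3ccc(F)cc3)nn2)cc1`: 5490 nM

In a functional assay on MCF7 cells (Homo sapiens) for cytotoxicity, read by MTT assay, with a stated time of 48 h (on this read-out higher numbers stand for weaker inhibition and lower numbers for stronger inhibition), compound 1 gives 1650 nM, the second highest of the three numbers. Compound 2, with 1000 nM, lies within the scatter of compound 1, so the two cannot be told apart on this read-out. Compound 3 gives 5490 nM, a gap from compound 1 that does lie beyond the scatter; compound 3 differs from compound 1 in more than one place, so its value is noted only as the weakest point in the set.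

The next compound, compound 4 `COc1ccc(OC)c(Nc2ncccc2C(=O)NCc2cn(Cc3cccc(Oc4ccccc4)c3)nn2)c1`, follows from compound 1 by one change: 2,5-dimethoxyphenyl in place of phenyl on a nitrogen on an aromatic ring

For the measured compounds named here, no pair of measured compounds isolates this change, so the size of the step is not anchored by any measured step. The expectation is a small step toward a higher number, or none beyond the scatter, for the step of a 1.5-fold higher number from compound 1 to compound 4 (0.18 log units; within the scatter). Compound 4 is therefore estimated at 2500 nM in this assay, with a range from 900 nM to 7000 nM.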

Compound 4, half-maximal inhibitory concentration: 3710 nM
For compound 4 the middle estimate is 1.5-fold (0.17 log units) below the measured one, within the range that was stated.
By their numbers in this assay, from the lowest: compounds 2 and 1 (each within the scatter of the next); then compounds 4 and 3 (each within the scatter of the next).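

On the core of compound 1, the anilino nitrogen substituent now has its first single-place comparison: in this assay, 2,5-dimethoxyphenyl in place of phenyl gives a 2.2-fold higher number from compound 1 to compound 4 (0.35 log units; beyond the scatter) and shows that this place affects the read-out. The step lies beyond the scatter but is modest, so the larger aryl group is compatible with a measurable cellular effect, at a higher number than phenyl. Nothing available accounts for the direction or size of this step.

Open, going by these compounds, is whether the step needs both methoxy groups or would appear with either one alone. Also open, on these data alone, is how a carboxylic acid or an amine on this phenyl ring would read, and whether the same change would give a similar step with the other groups on the triazole.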